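The compounds below may be only part of what the source reports. "The series", "measured", "known", "first", "only" and "open" are said of these compounds alone.

Values so far in an ADME assay on LLC-MK2 cells (Macaca mulatta) for cytotoxicity, read by spectrophotometry and crystal violet staining, with a stated time of 4 days; on this read-out higher numbers stand for lower toxicity in this test and lower numbers for higher toxicity in this test:
compound 1 `CC(C)n1ncc2c(C(=O)Nc3cccc(C(N)=O)c3)cc(-c3cccs3)nc21` gives 25000 nM
compound 2 `CC(C)n1ncc2c(NC(=O)c3ccc(F)cc3)cc(-c3cccs3)nc21` gives 50000 nM
compound 3 `CNS(=O)(=O)c1cccc(NC(=O)c2cc(-c3cccs3)nc3c2cnn3C(C)C)c1` gives 25000 nM

Compound 1 stands level with compound 3, and the number for compound 2 lies within the scatter of compound 1, so this read-out does not separate these compounds. Compound 4 `CC(C)n1ncc2c(C(=O)Nc3ccc(F)cc3F)cc(-c3cccs3)nc21` has not yet been measured. It differs from compound 1 by 2,4-difluorophenyl in place of 3-carbamoylphenyl on an amide-type nitrogen. Among the measured compounds shown here, only one measured step bears directly on this: no change at the digits printed from compound 1 to compound 3 (within the scatter) with methylsulfamoyl in place of carbamoyl on an aromatic carbon. That step alters the carbamoyl group that compound 4 loses, but it does not show what losing that group does, so its support is partial. Compound 2 also carries a fluorinated phenyl, and its amide differs from that of compound 1, so compound 2 with its value of 50000 nM is only loose support. No measured number points outside this narrow band. The step expected in this assay is a 1.4-fold higher number from compound 1 to compound 4 (0.15 log units; within the scatter) and thus none beyond the scatter. For compound 4 the estimated value is 35000 nM with an expected range from 15000 nM to 80000 nM on this read-out.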

Compound 4, half-maximal cytotoxic concentration: > 200000 nM
Compound 4 ended at the assay's limit; the forecaster's own chance of this, stated with the estimate: 20%; at least 5.7-fold (0.75 log units) between middle value and limit.
By their numbers in this assay, from the lowest: compounds 1, 3 and 2 (each within the scatter of the next). At a limit, above all of these: compound 4.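

In this assay the group on the amide-type nitrogen can move the read-out beyond the scatter, with 2,4-difluorophenyl in place of 3-carbamoylphenyl giving an at least 8.0-fold higher number from compound 1 to compound 4 (0.90 log units; beyond the scatter), whereas methylsulfamoyl in place of carbamoyl gave no change at the digits printed from compound 1 to compound 3 (within the scatter). Among the compounds shown here, this change removes the carbamoyl group, with its 1 hydrogen-bond donor and 1 hydrogen-bond acceptor, and brings in 2 fluorine atoms, so the one step cannot be assigned to either part alone. The reading for compound 4 is a limit of the assay and not a number, so the step gives a lower bound on the gap and not its size: the limit of > 200000 nM in this assay, at which 1 of the 4 values shown sits.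

Still open, from the compounds shown here alone, is whether removing the carbamoyl group or adding the fluorine atoms accounts for the step, a question that plain phenyl or 4-fluorophenyl on the same nitrogen would address. Also open, going by these compounds, is how far the effect extends to other groups on that ring, such as an amine or a carboxylic acid, and whether a single fluorine gives a reading within range of this assay.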